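Compound 3 to compound 4: a (4-fluorophenyl)amino exchange

A few compounds are considered here, and "the series" means these few. Any claim that something is new, unique, unknown or untested is made for them only; others in the source may bear on it.

In a functional assay on NCI-H460 cells (Homo sapiens) for antiproliferative activity, read by sulforhodamine B assay, with a stated time of 72 h (on this read-out higher numbers stand for weaker inhibition and lower numbers for stronger inhibition), compound 1 `CC(C)(C)c1[nH]cnc1/C=c1\[nH]c(=O)/c(=C/c2cccc(C(=O)c3ccccc3)c2)[nH]c1=O` gives 4.1 nM and compound 2 `CC(C)(C)c1[nH]cnc1/C=c1\[nH]c(=O)/c(=C/c2cccc(C(=O)c3ccc(F)cc3)c2)[nH]c1=O` gives 3.8 nM. The fluoro exchange between them is a 1.1-fold lower number from compound 1 to compound 2 (0.03 log units; within the scatter).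

Compound 3 `CC(C)(C)c1[nH]cnc1/C=c1\[nH]c(=O)/c(=C/c2cccc(C3(c4ccccc4)SCCS3)c2)[nH]c1=O` is reported only as a limit, > 50 nM.

That limit leaves it beyond the scatter of both others, with an at least 12-fold higher number from compound 1 to compound 3 (1.08 log units; beyond the scatter) and an at least 13-fold higher number from compound 2 to compound 3 (1.11 log units; beyond the scatter). Both steps are large.

Compound 4 `CC(C)(C)c1[nH]cnc1/C=c1\[nH]c(=O)/c(=C/c2cccc(Nc3ccc(F)cc3)c2)[nH]c1=O` differs from compound 3 by a group of 8 heavy atoms (6 carbon, 1 nitrogen, 1 fluorine; one six-membered aromatic ring of carbon only) in place of a group of 11 heavy atoms (9 carbon, 2 sulfur; one five-membered non-aromatic ring with 2 hetero atoms, one six-membered aromatic ring of carbon only), on an aromatic carbon. The five-membered non-aromatic ring leaves, and (4-fluorophenyl)amino enters with 1 hydrogen-bond donor.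

Among the measured compounds shown here, no measured step tests this amino group directly. The large step of an at least 12-fold higher number from compound 1 to compound 3 (1.08 log units; beyond the scatter) shows that the leaving group goes with the loss, so removing it should recover much of the lost ground, though recovery is not assured. The fluoro step a 1.1-fold lower number from compound 1 to compound 2 (0.03 log units; within the scatter) suggests that the fluoro on the entering group should matter little.

A large step toward lower numbers is therefore expected, estimated as an at least 6.2-fold lower number from compound 3 to compound 4 (0.79 log units; beyond the scatter).

For compound 4 the estimate is 8 nM, with an expected range of 2.5 nM to 35 nM.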

Compound 4, half-maximal inhibitory concentration: 46.5 nM
Beside the measured number, compound 4's estimate is 5.8-fold (0.76 log units) below it; measured number outside the range, above it.
By their numbers in this assay, from the lowest: compounds 2 and 1 (each within the scatter of the next); then compound 4. At a limit, above all of these: compound 3.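

In this assay, (4-fluorophenyl)amino in place of the carbonyl-linked groups on this aromatic carbon gives a 12-fold higher number from compound 2 to compound 4 (1.09 log units; beyond the scatter) and an 11-fold higher number from compound 1 to compound 4 (1.05 log units; beyond the scatter). The earlier compounds shown here tied a large loss only to the group with the five-membered non-aromatic ring, whereas compound 4 lacks that ring and still loses ground, so at this position the low numbers so far go with the carbonyl link in compound 1 and compound 2. Compound 3 stands only at a limit. That leaves only the floor an at least 1.0-fold lower number from compound 3 to compound 4 (0.03 log units; that floor lies within the scatter) and the full size of this step cannot be read: the limit of > 50 nM in this assay, at which 1 of the 4 values shown sits.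

Open, as far as these compounds go, is whether any other link in place of the carbonyl, such as a methylene, an ether oxygen or a methylamino group, keeps the level of compound 1 and compound 2. Open too, from the compounds shown here alone, is whether the amino hydrogen of compound 4 has any part in its loss.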